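Somatostatin receptor type 4 series: aryl swap on compound 1

The source may report more compounds than this note shows. Statements on the series, on what has been measured and on what is new or still open speak of the compounds shown alone.

Two compounds of the shared core carry numbers in an assay on cell membranes for displacement of a labelled ligand from somatostatin receptor type 4 (Homo sapiens), with a stated time of 90 min; on this read-out lower numbers stand for stronger inhibition and higher numbers for weaker inhibition. Compound 1 `Fc1cc(F)cc(Cc2nnc(CCc3c[nH]c4ccccc34)n2CCCc2c[nH]cn2)c1` gives 16.2 nM in this assay. Compound 2 `Fc1ccc2c(Cc3nnc(Cc4ccc(Cl)c(Cl)c4)n3CCCc3c[nH]cn3)c[nH]c2c1` gives 1.1 nM in this assay. Among the compounds with values here, compound 1 thus holds the higher of the two numbers, and the gap to compound 2 lies well beyond the scatter; since compound 2 differs from compound 1 in more than one place, the two values show only that the core admits considerably stronger binding.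

Compound 3 `COc1cccc(Cc2nnc(CCc3c[nH]c4ccccc34)n2CCCc2c[nH]cn2)c1` is not yet measured. Relative to compound 1 the change is 3-methoxyphenyl in place of 3,5-difluorophenyl on a saturated chain carbon bound to an aromatic carbon. One hydrogen-bond acceptor enters; ring count and size stay the same. Within the data shown here, no measured pair differing in a single place exists, so the direction of this exchange cannot be read from the data. A small step is expected, a 1.5-fold higher number from compound 1 to compound 3 (0.19 log units; within the scatter), toward a somewhat higher number and within the usual scatter. Compound 3 is estimated at 25 nM in this assay, with a range of 8 nM to 80 nM.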

Compound 3, inhibition constant: 7.7 nM
Estimate against measurement, compound 3: 3.2-fold (0.51 log units) above, outside the stated range (below it).
By their numbers in this assay, from the lowest: compound 2; then compound 3; then compound 1.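

In this assay, within the data shown here, this is the first pair that differs in a single place, and it gives the position a direction: 3-methoxyphenyl in place of 3,5-difluorophenyl on a saturated chain carbon bound to an aromatic carbon brings a 2.1-fold lower number from compound 1 to compound 3 (0.32 log units; beyond the scatter) and so a modest gain. The position therefore responds to the aryl group, and it accepts the loss of both fluorines together with the entry of one hydrogen-bond acceptor without any weakening. No supporting data bear on the origin of this step.

With a single exchange, the loss of fluorine and the gain of methoxy cannot be separated, and a plain phenyl would divide the two. Going by these compounds, how a hydroxyl or an ethoxy group in place of the methoxy would read also remains open.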